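The source may report more compounds than this note shows. Statements on the series, on what has been measured and on what is new or still open speak of the compounds shown alone.

Compound 1 `N#Cc1cc(-c2nc(C(c3ccc(F)cc3)c3ccc(F)cc3)sc2CC(=O)O)ccc1F` is the anchor of this small set. In an in vitro functional assay on HEK285-7 cells for antagonist activity at prostaglandin D2 receptor 2 (Homo sapiens), read by BRET and beta-arrestin recruitment (a lower number here means a stronger inhibitor, a higher number a weaker inhibitor), compound 1 gives 520 nM, the lowest of the two numbers that have been obtained. Compound 2 `Cc1nc(-c2ccc(Cl)cc2)c(CC(=O)O)s1` sits far from it: in this assay compound 2 gives 41000 nM, and the gap between compound 2 and compound 1 lies well beyond the usual scatter. Compound 3 `CCC(c1ccccc1)c1nc(-c2ccc(Cl)cc2)c(CC(=O)O)s1` is reported only as a limit of the assay, (the limit of > 100000 nM in this assay, at which 1 of the 3 values shown sits), and in this assay compound 3 gives > 100000 nM, so no number is available for it.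

Compound 4 `O=C(O)Cc1sc(C(c2ccc(F)cc2)c2ccc(F)cc2)nc1-c1cc(F)cc(F)c1` has not yet been measured. It differs from compound 1 in a single place: 3,5-difluorophenyl in place of 3-cyano-4-fluorophenyl on an aromatic carbon. Going by the values given here, no measured pair among the three compounds shows a change of this kind, so the expectation rests on compound 1 alone, with the nitrile of compound 1 removed and a second fluorine added. The step of a 2.9-fold higher number from compound 1 to compound 4 (0.46 log units; beyond the scatter) is expected to be a modest move toward a higher number, roughly at the edge of the scatter rather than a large loss. Compound 4 is therefore estimated to give 1500 nM in this assay, within a range from 300 nM to 8000 nM.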

Compound 4, half-maximal inhibitory concentration: 340 nM
Estimate against measurement, compound 4: 4.4-fold (0.64 log units) above; low and high end bracket the measured number.
By their numbers in this assay, from the lowest: compounds 4 and 1 (each within the scatter of the next); then compound 2. At a limit, above all of these: compound 3.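

Going by these compounds alone, the exchange of 3-cyano-4-fluorophenyl for 3,5-difluorophenyl, on the aromatic carbon next to the ring nitrogen, gives the first one-place comparison in this set: in this assay it is a 1.5-fold lower number from compound 1 to compound 4 (0.18 log units; within the scatter), so compound 1 and compound 4 cannot be told apart. The nitrile is therefore not needed to keep the number in this range for this pair, and a phenyl group carrying only two fluorines serves at this position as well as the cyano-bearing one, something compounds 2 and 3 could not show, as each differs from compound 1 in more than one place. Within the data shown here, nothing measured here explains why the two groups read alike, and the one limit among the values does not bear on this step.

Among these compounds, the single step exchanges the nitrile and the fluorine pattern together, so what each contributes alone stays unresolved, and one pair sets no rule for this position. Also open, going by these compounds, is whether a methoxy group or an amine on this phenyl ring would stay within the scatter of compound 1, or would move the number beyond it.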